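The source may hold more compounds than are shown below. What is called first, only, known or untested is meant among the compounds shown, and "the series" means these compounds.

Compound 1 `Cc1nc(-c2ccccc2)c(C(=O)N2CCN(c3cccc(C)c3C)CC2)o1` has been tested in a functional assay on HL-60 cells (Homo sapiens) for inhibition, read by MTT assay, with a stated time of 72 h; a higher number here means a weaker inhibitor, a lower number a stronger inhibitor. In this assay compound 1 gives 35 nM. That is the lowest of the two numbers available. Compound 2 `COc1cc(OC)cc(N2CCN(C(=O)c3onc(C)c3-c3ccc(F)cc3)CC2)c1`, the nearest neighbour on the numbers, gives 475 nM in this assay, a gap that lies beyond the usual scatter of repeated measurements. Compound 3 `CCc1nc(-c2ccc(OC)c(OC)c2)c(C(=O)N2CCN(c3cccc(Cl)c3)CC2)o1` was reported as "not active" (no number reported) in this assay, with no number attached.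

The step to compound 4 `Cc1nc(-c2ccccc2)c(C(=O)N2CCN(c3ccccc3F)CC2)o1` changes only the group on the amine nitrogen in a ring: 2-fluorophenyl in place of 2,3-dimethylphenyl on an amine nitrogen in a ring. Within the data shown here, no measured pair in this set isolates that change, so the expectation rests on how compound 1 compares with its neighbours and on the nature of the swap. A modest loss of potency is expected, with the step from compound 1 to compound 4 estimated at a 2.6-fold higher number from compound 1 to compound 4 (0.41 log units; beyond the scatter). Compound 4 is therefore estimated to give about 90 nM in this assay, within a range from 25 nM to 400 nM.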

Compound 4, half-maximal inhibitory concentration: 147 nM
Estimate against measurement, compound 4: 1.6-fold (0.21 log units) below; the range from low to high includes it.
By their numbers in this assay, from the lowest: compound 1; then compound 4; then compound 2.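

Among these compounds, replacing 2,3-dimethylphenyl with 2-fluorophenyl on the amine nitrogen in a ring gives the first direct reading at this position. In this assay the result is a 4.2-fold higher number from compound 1 to compound 4 (0.62 log units; beyond the scatter) and so a modest loss of potency, which shows that the group on this nitrogen affects the number but that this swap does not abolish activity. Nothing available here explains the shift.

The change removes two methyl groups and adds a fluorine in a single step, so the contribution of each remains unresolved. An unsubstituted phenyl or a 2-methylphenyl on the same nitrogen, with the rest of compound 1 unchanged, would help to separate them.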